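Chalcone-triazole-coumarin series: replacing the trimethoxyphenyl end

The compounds below may be only part of what the source reports. "The series", "measured", "known", "first", "only" and "open" are said of these compounds alone.

Measured so far:
compound 1 `COc1cc(/C=C/C(=O)/C=C/c2cc(OC)c(OC)c(OC)c2)ccc1OCc1cn(CCOc2cc(=O)oc3ccccc23)nn1`: 99%
compound 2 `COc1ccccc1/C=C/C(=O)/C=C/c1ccc(OCc2cn(CCCCOc3cc(=O)oc4ccccc34)nn2)c(OC)c1`: 40%
compound 3 `COc1cc(/C=C/C(=O)/C=C/c2ccco2)ccc1OCc1cn(CCCCCOc2cc(=O)oc3ccccc23)nn1`: 39%

Three compounds of the series have been run in a functional assay on THP-1 cells (Homo sapiens) for inhibition, read by sulforhodamine B assay, with a stated time of 48 h, tested at 50 uM; on this read-out higher numbers stand for more inhibition of growth at the one concentration tested and lower numbers for less inhibition of growth. Compound 1 gives 99%, the highest of the three numbers. Compound 2 gives 40% and compound 3 gives 39%; both lie below compound 1 by gaps well beyond the usual scatter, and the two of them sit within the scatter of each other. Among the compounds with values here, no pair among the measured compounds differs in a single place, so none of these gaps can be tied to one structural change; compound 2 and compound 3 differ from compound 1 at the aryl end and in the chain on the triazole at the same time.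

Compound 4 `COc1cc(/C=C/C(=O)/C=C/c2cccs2)ccc1OCc1cn(CCOc2cc(=O)oc3ccccc23)nn1` has not yet been measured. It differs from compound 1 in one place: thiophen-2-yl in place of 3,4,5-trimethoxyphenyl on a double-bonded chain carbon bound to a double-bonded chain carbon. The rest of the molecule, including the two-carbon chain to the coumarin oxygen, is kept from compound 1.

Since every other departure from compound 1 at the aryl end has so far come with a clearly lower number, the step from compound 1 to compound 4 is expected to be a decrease beyond the scatter, a number 34 percentage points lower from compound 1 to compound 4 (beyond the scatter). Compound 4 is accordingly estimated at 65%, with a range from 30% to 95%.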

Compound 4, percent growth inhibition at one concentration: 76%
For compound 4 the middle estimate is 11 percentage points below the measured one; the measured number falls inside the stated range.
By their numbers in this assay, from the lowest: compounds 3 and 2 (each within the scatter of the next); then compound 4; then compound 1.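

In this assay, within the data shown here, a number 23 percentage points lower from compound 1 to compound 4 (beyond the scatter) is the first change at the aryl end that can be read alone, since the chain on the triazole stays as in compound 1 and only thiophen-2-yl replaces 3,4,5-trimethoxyphenyl. The 3,4,5-trimethoxyphenyl group is therefore not required for substantial growth inhibition at this place: with 5 heavy atoms and 1 hydrogen-bond acceptor in the entering group, fewer of each than in the group that leaves, compound 4 still gives 76%, although the exchange carries a cost beyond the scatter. No measurement at hand gives a reason for this step.

The contributions of the aryl end and the chain on the triazole to the lower numbers of compound 2 and compound 3 remain unresolved, as the steps from those compounds to the others cannot be read. Also open, going by these compounds, is how a pyridine ring or a phenyl ring carrying a carboxylic acid would fare on a double-bonded chain carbon bound to a double-bonded chain carbon, with the rest of compound 1 kept, and whether a longer chain would change the effect of thiophen-2-yl.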